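The compounds below may be only part of what the source reports. "The series", "measured", "known", "first", "only" and "open" are said of these compounds alone.

Compound 1 `COc1cc2c(cc1OC)C(CC(=O)O)CC2` gives 18.8% in a functional assay on the whole organism (strain Wistar) for inhibition, with Rattus norvegicus as the target, read by paw edema, with a stated time of 1 h, at a dose of 100 mg/kg; a higher number here means more inhibition at the dose given (going by the name of the read-out), a lower number less inhibition.
Compound 2 `COc1cc2c(cc1OC)C(CC(=O)Nc1cccc(Cl)c1)CC2` gives 31.3%.
Compound 3 `COc1cc2c(cc1OC)C(CC(=O)Nc1ccc(Br)cc1)CC2` gives 50%.

Compound 3 stands highest of the three measured compounds, with a number 18.7 percentage points higher from compound 2 to compound 3 (beyond the scatter) and a number 31.2 percentage points higher from compound 1 to compound 3 (beyond the scatter), both beyond the scatter. Compound 4 `COc1cc2c(cc1OC)C(CC(=O)Nc1cccc(C)c1)CC2` has not been measured; it differs from compound 3 by 3-methylphenyl in place of 4-bromophenyl on an amide-type nitrogen. For the measured compounds named here, the steps that bear on this are the two amide formations from compound 1: a number 12.5 percentage points higher from compound 1 to compound 2 (beyond the scatter) with a 3-chlorophenyl group, and a number 31.2 percentage points higher from compound 1 to compound 3 (beyond the scatter) with a 4-bromophenyl group. Going by the values given here, the 3-chlorophenyl amide came out lower (a number 18.7 percentage points higher from compound 2 to compound 3 (beyond the scatter)), and no measured step compares a methyl with a halogen, so a modest drop is expected, a number 15 percentage points lower from compound 3 to compound 4 (beyond the scatter). Compound 4 is therefore estimated at 35%, within a range from 20% to 50%.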

Compound 4, a percentage reported as inhibition, in the whole organism at one dose (the size of the read-out at that dose, not a potency): 37.5%
Estimate against measurement, compound 4: 2.5 percentage points below; the measured number falls inside the stated range.
By their numbers in this assay, from the lowest: compound 1; then compounds 2 and 4 (each within the scatter of the next); then compound 3.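

Methyl in place of chloro on the aromatic carbon gives a number 6.2 percentage points higher from compound 2 to compound 4 (within the scatter) in this assay, so these two groups cannot be told apart here. The 3-methylphenyl amide keeps a gain over the acid, with a number 18.7 percentage points higher from compound 1 to compound 4 (beyond the scatter), but the 4-bromophenyl amide stays ahead, with a number 12.5 percentage points lower from compound 3 to compound 4 (beyond the scatter). Nothing measured here explains these steps. As far as these compounds go, whether the higher number of compound 3 goes with the bromine or with the 4 position of its ring stays open. A 4-methylphenyl or 3-bromophenyl group on the amide nitrogen would separate the two.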